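Adding an Isopropylamino Group Where the Core Carries Hydrogen

The source may hold more compounds than are shown below. What is called first, only, known or untested is meant among the compounds shown, and "the series" means these compounds.

Measured so far:
compound 1, `Fc1ccc(-c2nn3ccc(Cl)cc3c2-c2ccnc(NC3CCCC3)n2)cc1`: > 40000 nM
compound 2, `Nc1ccn2nc(-c3ccc(F)cc3)c(-c3ccnc(NC4CCCC4)n3)c2c1`: 20000 nM

Of the compounds shown here, two have been tested in an ADME assay on Vero cells (Chlorocebus sabaeus) for cytotoxicity; a lower number here means that less compound is tolerated, a higher number that more compound is tolerated. For compound 1 the read-out > 40000 nM is a limit of the assay, not a number (the limit of > 40000 nM in this assay, at which 1 of the 2 values shown sits). Compound 2 gives 20000 nM in this assay. Among the compounds with values here, the one step between them, an at least 2.0-fold lower number from compound 1 to compound 2 (0.30 log units; that floor lies within the scatter), came with amino in place of chloro on an aromatic carbon, and its size lies at a floor that falls within the scatter.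

Compound 3, `CC(C)Nc1cc(Cl)cc2c(-c3ccnc(NC4CCCC4)n3)c(-c3ccc(F)cc3)nn12`, keeps the chloro of compound 1 and differs from it by isopropylamino in place of hydrogen on an aromatic carbon. Within the data shown here, no measured step touches that position, so the step from compound 1 to compound 2 bears on it only loosely: one change on the shared core did not move the number beyond the scatter. The expected step is therefore a number no higher from compound 1 to compound 3 (the limit leaves the size open), not beyond the scatter in either direction. The estimate for compound 3 in this assay is 40000 nM, expected to fall between 15000 nM and 90000 nM.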

Compound 3, half-maximal cytotoxic concentration: > 40000 nM
Compound 3: a limit, no number; the forecaster's own chance of this, stated with the estimate: 50%; the middle value sits exactly at the limit.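

In this assay compound 3 gives > 40000 nM, a limit and not a number, and compound 1 stands at a limit too, so no step between compound 1 and compound 3 can be read: the limit of > 40000 nM in this assay, at which 2 of the 3 values shown sit.

On these data alone, whether isopropylamino in place of hydrogen on an aromatic carbon changes the read-out at all stays open.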